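The source may hold more compounds than are shown below. What is called first, only, known or untested is meant among the compounds shown, and "the series" means these compounds.

Compound 1 `O=C(O)c1c(-c2ccc([N+](=O)[O-])cc2)oc2ccccc2c1=O`: in a functional assay on HT-29 cells (Homo sapiens) for cytotoxicity, read by MTT assay, with a stated time of 6 days (a higher number here means that more compound is needed for the effect, a lower number that less compound is needed), compound 1 gives > 25 ug/mL, which is a limit of the assay and not a number.
Compound 2 `COc1ccc2c(=O)c(C(=O)O)c(-c3ccc([N+](=O)[O-])cc3)oc2c1`: in this assay compound 2 gives > 25 ug/mL, again a limit.
Compound 3 `COc1ccc2c(=O)cc(-c3cc(OC)c(OC)c(OC)c3)oc2c1`: in this assay compound 3 gives > 25 ug/mL, also a limit.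

Compound 2 differs from compound 1 by methoxy in place of hydrogen on an aromatic carbon. Since both results are limits, the step that the two limits leave unreadable from compound 1 to compound 2 cannot be read; the only firm point is the limit of > 25 ug/mL in this assay, at which 3 of the 3 values shown sit.

Compound 4 `COc1cc(-c2cc(=O)c3ccc(OC)c(OC)c3o2)cc(OC)c1OC` has not yet been measured. It differs from compound 3 by methoxy in place of hydrogen on an aromatic carbon. Going by the values given here, this is the same kind of change as the one from compound 1 to compound 2, but the surroundings are not the same: in compound 2 the methoxy sits meta to a fused ring and para to a fused ring, whereas in compound 4 it sits ortho to a fused ring, ortho to a methoxy group and meta to a fused ring. How the core of compound 3 differs from the core of compound 1 is not broken down here.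

With the earlier step unreadable, the step that the limit leaves unreadable from compound 3 to compound 4 is expected to be small, resting only on (the limit of > 25 ug/mL in this assay, at which 3 of the 3 values shown sit). Compound 4 is therefore expected to give about 30 ug/mL in this assay, most likely reported again only as a limit, with a plausible span from 10 ug/mL to 100 ug/mL.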

Compound 4, concentration for half-maximal effect: > 25 ug/mL
Compound 4: no number, only a limit (the forecaster's own chance of this, stated with the estimate: 80%); the middle value lies beyond the limit too.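

In this assay compound 4 gives > 25 ug/mL, which is a limit and not a number. Compound 3 also sits at a limit, so no size can be read for the change from compound 3 to compound 4. The compounds shown leave open how much of any of them is needed for the effect, and whether methoxy in place of hydrogen changes that at all: the limit of > 25 ug/mL in this assay, at which 4 of the 4 values shown sit.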